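This account rests on a few compounds, and the source may have more. Where it says the series, first, only, none or still open, it means among the compounds named here.

Compound 1 `O=C(O)CN1C(=O)/C(=C/c2nc3ccccc3n2Cc2ccc(F)cc2)SC1=S` gives 4860 nM in a functional assay on PC-3 cells (Homo sapiens) for cytotoxicity, read by MTT assay, with a stated time of 48 h; a higher number here means a weaker inhibitor, a lower number a stronger inhibitor.
Compound 2 `O=C(O)CN1C(=O)/C(=C/c2nc3ccccc3n2Cc2ccc(C(F)(F)F)cc2)SC1=S` gives 22900 nM in this assay.

Among these two numbers compound 2 stands highest; its only neighbour is compound 1, and the single measured step, a 4.7-fold higher number from compound 1 to compound 2 (0.67 log units; beyond the scatter), links them. Compound 3 `COc1cc(Cn2c(/C=C3\SC(=S)N(CC(=O)O)C3=O)nc3ccccc32)cc(OC)c1` has not been measured; the change from compound 2 is 3,5-dimethoxyphenyl in place of 4-(trifluoromethyl)phenyl on a saturated chain carbon bound to an aromatic nitrogen. For the measured compounds named here, no measured step swaps a 4-(trifluoromethyl)phenyl for a 3,5-dimethoxyphenyl, so the bearing of the data is indirect: the step of a 4.7-fold higher number from compound 1 to compound 2 (0.67 log units; beyond the scatter) shows that exchanging the group on the saturated chain carbon bound to the aromatic nitrogen can move the number by a modest amount, and in either direction in principle. As compound 2 already stands at the top of the range, the expectation for compound 3 is a step of a 1.9-fold lower number from compound 2 to compound 3 (0.28 log units; within the scatter), with wide uncertainty. The estimate for compound 3 in this assay is 12000 nM, within 4000 nM to 40000 nM.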

Compound 3, half-maximal inhibitory concentration: 6370 nM
The estimate for compound 3 lay 1.9-fold (0.28 log units) above the measured number; low and high end bracket the measured number.
By their numbers in this assay, from the lowest: compounds 1 and 3 (each within the scatter of the next); then compound 2.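

In this assay, the place on a saturated chain carbon bound to an aromatic nitrogen now shows a second exchange beyond the scatter, with a 3.6-fold lower number from compound 2 to compound 3 (0.56 log units; beyond the scatter) as 3,5-dimethoxyphenyl enters for 4-(trifluoromethyl)phenyl. By contrast, 3,5-dimethoxyphenyl and 4-fluorophenyl cannot be told apart at this place, with a 1.3-fold higher number from compound 1 to compound 3 (0.12 log units; within the scatter), so among these three groups only 4-(trifluoromethyl)phenyl stands apart. No measurement here accounts for this difference.

Open is whether the two methoxy groups are both needed to stay level with compound 1, since a phenyl with no substituent and a phenyl with a single methoxy group are absent from the compounds shown. Also open, as far as these compounds go, is how an amine on the ring or a longer chain in place of the saturated chain carbon would read.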